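Bromo for nitro on the hydrazone aryl ring

A few compounds are considered here, and "the series" means these few. Any claim that something is new, unique, unknown or untested is made for them only; others in the source may bear on it.

Measured compounds:
compound 1 `O=C(COc1cccc2ccccc12)N/N=C/c1cccc([N+](=O)[O-])c1`, 3.97
compound 2 `C/C(=N\NC(=O)COc1cccc2ccccc12)c1ccc(O)cc1`, 4.44
compound 3 `C/C(=N\NC(=O)COc1cccc2ccccc12)c1ccc([N+](=O)[O-])cc1`, 3.37

In a physicochemical assay for lipophilicity, measured as octanol-water partition (on this read-out higher numbers stand for higher lipophilicity and lower numbers for lower lipophilicity), compound 1 sits second highest of the three numbers: compound 2 lies above it, compound 3 below it, both gaps beyond the scatter. For the measured compounds named here, the one step measured, a number 1.07 log units lower from compound 2 to compound 3 (beyond the scatter), is a large drop and involves the nitro group entering.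

Compound 4 `O=C(COc1cccc2ccccc12)N/N=C/c1cccc(Br)c1` differs from compound 1 as follows: bromo in place of nitro on an aromatic carbon. The change sits on an aromatic carbon of a six-membered aromatic ring of carbon only, meta to a large group. Going by the values given here, no step for bromo exists among the measured compounds, so the only guide is the nitro step, read in reverse: the nitro leaving compound 1 is expected to push the number up, and a step beyond the scatter in the upward direction is expected, a number 0.93 log units higher from compound 1 to compound 4 (beyond the scatter). Compound 4 is therefore estimated at 4.9, with a range from 4.4 to 5.4.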

Compound 4, partition coefficient: 4.81
Compound 4: middle estimate off by 0.09 log units, on the high side; the range from low to high includes it.
By their numbers in this assay, from the lowest: compound 3; then compound 1; then compound 2; then compound 4.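

In this assay bromo in place of nitro gives a number 0.84 log units higher from compound 1 to compound 4 (beyond the scatter) on an aromatic carbon meta to a large group, the first step read at this position. The earlier step, a number 1.07 log units lower from compound 2 to compound 3 (beyond the scatter) with nitro in place of hydroxy, had a different group as partner to nitro. In both pairs the compound carrying nitro has the lower number, and no compound shown goes against this.

Going by these compounds, whether an amine, a carboxylic acid or a methoxy group on this same aromatic carbon would fall nearer compound 1 or compound 4 remains open. No pair shown differs only in the methyl group on the hydrazone carbon, so that change cannot be read on its own. No measurement shown accounts for the new step.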